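Removing a Methyl from the Pyridazinone Core

This account rests on a few compounds, and the source may have more. Where it says the series, first, only, none or still open, it means among the compounds named here.

The study concerns three compounds measured for gastric inhibition and one whose number is still to come. Compound 1 `Cc1cc(=O)n(CCC(=N)S)nc1-c1ccccc1` gives 32% in a functional assay on the whole organism (stomach) for inhibition, with Rattus norvegicus as the target, at a dose of 100 mg/kg by the intraduodenal route (on this read-out higher numbers stand for more inhibition at the one dose given (going by the name of the read-out) and lower numbers for less inhibition), and stands second highest of the three numbers. Its nearest neighbour is compound 2 `O=c1cccnn1CCC(=S)N1CCCC1` with 29.7%, a difference that lies within the scatter of this assay. The furthest is compound 3 `N=C(S)CCn1nc(-c2ccc(Cl)c(Cl)c2)ccc1=O` with 55.8%, which lies beyond the scatter above compound 1. None of these three pairs differs in a single place, so no single step can be read from them.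

Compound 4 `N=C(S)CCn1nc(-c2ccccc2)ccc1=O` is the untested member. Compared with compound 1 it shows (hydrogen in place of methyl on an aromatic carbon). For the measured compounds named here, no measured pair shows what this particular change does, so the expectation rests only on the values of compound 1 and its companions. The step from compound 1 to compound 4 is expected to be a number 3 percentage points higher from compound 1 to compound 4 (within the scatter), that is, nothing beyond the scatter in this assay. Compound 4 is accordingly estimated at 35%, with a range from 15% to 55%.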

Compound 4, a percentage reported as inhibition, in the whole organism at one dose (the size of the read-out at that dose, not a potency): 53.7%
For compound 4 the middle estimate is 18.7 percentage points below the measured one; low and high end bracket the measured number.
By their numbers in this assay, from the lowest: compounds 2 and 1 (each within the scatter of the next); then compounds 4 and 3 (each within the scatter of the next).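

In this assay, hydrogen in place of methyl on the aromatic carbon ortho to a phenyl group comes with a number 21.7 percentage points higher from compound 1 to compound 4 (beyond the scatter). This shows that the position is not indifferent: the loss of a single methyl, with no hydrogen-bond donors or acceptors and no net charge involved, moves the number beyond the scatter, and the compound with hydrogen reads higher at the one dose given. No measurement shown here bears on the reason for this step.

With only methyl and hydrogen shown at this carbon, it remains open whether an ethyl, a methoxy or an amine there would read nearer to compound 1 or to compound 4. From the compounds shown here alone, it also remains open whether the same change would give a similar step in compounds with another group on the phenyl ring.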